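A few compounds are considered here, and "the series" means these few. Any claim that something is new, unique, unknown or untested is made for them only; others in the source may bear on it.

Measured so far:
compound 1 `Cn1ccc2cc(Nc3ncc4cc(S(=O)(=O)c5ccc(F)cc5F)c(=O)n(C)c4n3)ccc21` — 750 nM
compound 2 `O=c1[nH]c2nc(Nc3ccc4[nH]ccc4c3)ncc2cc1S(=O)(=O)c1ccc(F)cc1F` — 15000 nM
compound 3 `Cn1c(=O)c(S(=O)(=O)c2ccc(F)cc2)cc2cnc(Nc3ccc4[nH]cnc4c3)nc21` — 10000 nM

In a functional assay on DU-145 cells (Homo sapiens) for inhibition, read by trypan blue exclusion, with a stated time of 72 h (a lower number here means a stronger inhibitor, a higher number a weaker inhibitor), compound 2 gives the highest number of the three. Compound 3 gives 10000 nM, a gap to compound 2 that lies within the scatter, so no order between those two is claimed. Compound 1 gives 750 nM, a gap to compound 2 that is well beyond the scatter.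

Compound 4 `CCn1c(=O)c(S(=O)(=O)c2ccc(F)cc2F)cc2cnc(Nc3ccc4[nH]ccc4c3)nc21` differs from compound 2 by one change: ethyl in place of hydrogen on an aromatic nitrogen. Going by the values given here, no step between measured compounds separates this change from other differences. Still, compound 1 carries a group on that same ring nitrogen and gives the lowest number shown, so a step in that direction, beyond the scatter, is expected. The step from compound 2 to compound 4 is estimated at a 6.0-fold lower number from compound 2 to compound 4 (0.78 log units; beyond the scatter). For compound 4 the expected value is 2500 nM, with a range from 800 nM to 8000 nM.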

Compound 4, half-maximal inhibitory concentration: 750 nM
For compound 4 the middle estimate is 3.3-fold (0.52 log units) above the measured one; measured number outside the range, below it.
By their numbers in this assay, from the lowest: compounds 1 and 4 (each within the scatter of the next); then compounds 3 and 2 (each within the scatter of the next).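

In this assay, going by these compounds alone, ethyl in place of hydrogen on the aromatic nitrogen gives a 20-fold lower number from compound 2 to compound 4 (1.30 log units; beyond the scatter) as a single change, the first step that isolates this position. Within the data shown here, the earlier compounds differed in more than one place, so only this step ties a large change in the number to substitution on this nitrogen. No measurement shown explains the size of this step.

On these data alone, whether a longer chain such as propyl would extend or reverse this step remains open. As far as these compounds go, the effect of a chain ending in an amine or a carboxylic acid on this nitrogen is also open.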